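Shortening the chain: cytotoxicity expected for compound 4

The source may report more compounds than this note shows. Statements on the series, on what has been measured and on what is new or still open speak of the compounds shown alone.

Compound 1 `CCCCCCCCCc1cc2cn(COCCO)c(O)nc-2n1` was tested in a functional assay on HEL cells (Homo sapiens), read by microscopy (on this read-out higher numbers stand for lower toxicity in this test and lower numbers for higher toxicity in this test), and gave only a limit, > 80000 nM. Two related compounds give a fuller picture. Compound 2 `O=c1nc2occc2cn1COCCO` returns a limit in this assay, > 400000 nM. Compound 3 `CCCCCCCCc1cc2cn(COCCO)c(=O)nc2o1` returns a limit as well, >= 80000 nM. All three measured compounds therefore sit at the edge of what this assay can detect, as the limit of > 400000 nM in this assay, at which 1 of the 3 values shown sits, the limit of > 80000 nM in this assay, at which 1 of the 3 values shown sits, and the limit of >= 80000 nM in this assay, at which 1 of the 3 values shown sits, show; none gives a real number. Compound 4 `CCCCCCCCc1cc2cn(COCCO)c(O)nc-2n1` is the compound still to be measured. It differs from compound 1 in one place: hydrogen in place of methyl on a saturated chain carbon, eight bonds along the chain from an aromatic carbon. Since compound 1 stands at a limit, > 80000 nM, the step of a number no higher from compound 1 to compound 4 (the limit leaves the size open) is expected to be none beyond the scatter. Compound 4 is thus expected to give 80000 nM, between 40000 nM and 400000 nM, most likely again reported as a limit.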

Compound 4, minimum cytotoxic concentration: 80000 nM
For compound 4 middle estimate and measured number coincide at the digits printed; low and high end bracket the measured number.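

In this assay compound 4 gives 80000 nM, a real number and not a limit, the only one among the compounds shown. Replacing methyl with hydrogen at this place therefore gives a number no higher from compound 1 to compound 4 (the limit leaves the size open). So this shorter chain can be placed on the scale of the test, but the effect of removing that methyl cannot be sized.

From the compounds shown here alone, it remains open how much chain length matters on this core. A longer chain, or a chain carrying an amine, could show whether the number moves at all.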